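The source may report more compounds than this note shows. Statements on the series, on what has been measured and on what is new or still open speak of the compounds shown alone.

In an assay on isolated protein for displacement of a labelled ligand from metabotropic glutamate receptor 5 (Homo sapiens), with a stated time of 60 min, tested at 1 uM (a lower number here means less inhibition, a higher number more inhibition at the concentration tested (going by the name of the read-out)), three compounds have been measured: compound 1 `CC1CCN(c2c(S(=O)(=O)c3ccc(Cl)c(Cl)c3)cnc3cc(F)ccc23)CC1` with 94%, compound 2 `Cc1ccc(S(=O)(=O)c2cnc3cc(F)ccc3c2N2CCC(C)CC2)cc1Cl` with 93%, and compound 3 `Cc1ccc(S(=O)(=O)c2cnc3ccc(Cl)cc3c2N2CCC(C)CC2)cc1` with 95%.

Compound 1 and compound 2 differ in one place, (methyl in place of chloro on an aromatic carbon), and that step reads a number 1 percentage points lower from compound 1 to compound 2 (within the scatter). Compound 4 `Cc1ccc(S(=O)(=O)c2cnc3ccc(C)cc3c2N2CCC(C)CC2)cc1` is not yet measured; it differs from compound 3 by methyl in place of chloro on an aromatic carbon. This is the same kind of change, not the same: in compound 4 the methyl sits on a ring that is part of a fused or bridged system of two rings, meta to a fused ring and para to a fused ring, whereas in compound 2 it sits ortho to a chloro group and para to a large group. The difference between the core of compound 1 and the core of compound 3 is not broken down here. Because the earlier step of a number 1 percentage points lower from compound 1 to compound 2 (within the scatter) stayed within the scatter, compound 4 is expected to move by a number 2 percentage points lower from compound 3 to compound 4 (within the scatter) in this assay. Compound 4 is thus estimated at 93%, between 85% and 98%.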

Compound 4, a percentage reported as inhibition, at one concentration (the size of the read-out at that concentration, not a potency): 82%
Beside the measured number, compound 4's estimate is 11 percentage points above it, and the stated range ends above it.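

In this assay methyl in place of chloro on an aromatic carbon gives a number 13 percentage points lower from compound 3 to compound 4 (beyond the scatter) and so has a readable effect on the core of compound 3. Set beside the earlier step, this result does not show that the change behaves differently on the two cores: the same change on two cores in this assay, a number 1 percentage points lower (within the scatter) from compound 1 to compound 2 and a number 13 percentage points lower (beyond the scatter) from compound 3 to compound 4, 12 percentage points apart, within the scatter of two such steps. Nor does it show that the change carries over unaltered, as only two pairs are available and the methyl sits at a different place in each.

The compounds shown leave open how a nitrile or an amine in place of the chloro would read in this assay. They also leave open whether a methoxy group at that place would follow the methyl.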